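Repositioning Chloro and Nitro Groups in a Growth-Inhibition Series

The source may report more compounds than this note shows. Statements on the series, on what has been measured and on what is new or still open speak of the compounds shown alone.

Compound 1 `O=C(/C=C/c1ccc(Cl)c([N+](=O)[O-])c1)/C=C/c1ccccc1Oc1ncnc2ccc(Cl)cc12` — 70.2%
Compound 2 `O=C(/C=C/c1ccc(Oc2ncnc3ccc(Cl)cc23)cc1)/C=C/c1ccc(Cl)c(Cl)c1` — 50.5%
Compound 3 `O=C(/C=C/c1ccc(Oc2ncnc3ccc(Cl)cc23)cc1)/C=C/c1cccc(Cl)c1Cl` — 68.5%

In a functional assay on MGC-803 cells (Homo sapiens) for inhibition, read by MTT assay, with a stated time of 72 h, tested at 10 uM (on this read-out lower numbers stand for less inhibition of growth and higher numbers for more inhibition of growth at the one concentration tested), compound 1 gives the highest of the three numbers; compound 3 lies within the scatter of it, while compound 2 lies beyond the scatter below it. Compound 4 `O=C(/C=C/c1cc([N+](=O)[O-])ccc1Cl)/C=C/c1ccccc1Oc1ncnc2ccc(Cl)cc12` has not yet been measured; it differs from compound 1 by 2-chloro-5-nitrophenyl in place of 4-chloro-3-nitrophenyl on a double-bonded chain carbon bound to a double-bonded chain carbon. Within the data shown here, the only measured step that resembles this change, a rearrangement of substituents on the same kind of ring, is a number 18 percentage points higher from compound 2 to compound 3 (beyond the scatter). That step concerns a dichlorophenyl rather than a chloro-nitrophenyl, so it bears only loosely on compound 4, and a step of similar modest size in either direction, or none beyond the scatter, seems plausible. Compound 4 is therefore expected to give 65% in this assay, within 48% to 80%, which means an expected step of a number 5.2 percentage points lower from compound 1 to compound 4 (within the scatter).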

Compound 4, percent growth inhibition at one concentration: 91.6%
Compound 4: the middle estimate sits 26.6 percentage points below what was measured; the whole stated range lies below it.
By their numbers in this assay, from the lowest: compound 2; then compounds 3 and 1 (each within the scatter of the next); then compound 4.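

In this assay, exchanging 4-chloro-3-nitrophenyl for 2-chloro-5-nitrophenyl gives a number 21.4 percentage points higher from compound 1 to compound 4 (beyond the scatter), so rearranging the same atoms on this ring matters for a chloro-nitrophenyl, not only for a dichlorophenyl. The direction matches that of a number 18 percentage points higher from compound 2 to compound 3 (beyond the scatter), although that step sits on a different compound pair. Nothing available accounts for the rise.

From the compounds shown here alone, it remains open whether an amine or a methoxy group in place of the nitro group would hold the number. Going by these compounds, whether 2-chloro-5-nitrophenyl gives a similar rise on the core of compound 2 is also open.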